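A few compounds are considered here, and "the series" means these few. Any claim that something is new, unique, unknown or untested is made for them only; others in the source may bear on it.

In a functional assay on K562 cells (Homo sapiens) for antiproliferative activity, read by MTT assay, with a stated time of 48 h (a higher number here means a weaker inhibitor, a lower number a stronger inhibitor), compound 1 `Cn1cc(C2=C(c3nn(CCCn4cncn4)c4ncccc34)C(=O)N(c3ccccc3)C2=O)c2ccccc21` gives > 100000 nM, which is a limit of the assay and not a number. Compound 2 `Cn1cc(C2=C(c3nn(CCn4ccnc4)c4ncccc34)C(=O)N(c3ccccc3)C2=O)c2ccccc21` reads 26400 nM. Among the compounds with values here, compound 3 `Cn1cc(C2=C(c3nn(CCCN4CCCCC4)c4ncccc34)C(=O)N(c3cccc4ccccc34)C2=O)c2ccccc21` reads 3180 nM, the lowest value so far, with compound 2 its nearest neighbour.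

Compound 4 `Cn1cc(C2=C(c3nn(CCCN4CCCCC4)c4ncccc34)C(=O)NC2=O)c2ccccc21` carries hydrogen in place of naphthalen-1-yl on an amide-type nitrogen in a ring.

Within the data shown here, the only measured single-place step is an at least 3.7-fold lower number from compound 1 to compound 2 (0.57 log units; beyond the scatter). It concerns a saturated chain carbon, not the amide-type nitrogen, so it bears only indirectly: it shows that one change can move the number in this assay beyond the scatter. Among the measured compounds shown here, no measured pair changes the group on that nitrogen, and the direction therefore remains open. The estimated step is a 1.3-fold higher number from compound 3 to compound 4 (0.10 log units; within the scatter), expected to stay within the scatter but with wide uncertainty. For compound 4, the expected value is 4000 nM, with an estimated range of 700 nM to 25000 nM.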

Compound 4, half-maximal inhibitory concentration: 5960 nM
Compound 4: middle estimate off by 1.5-fold (0.17 log units), on the low side; the measured number falls inside the stated range.
By their numbers in this assay, from the lowest: compounds 3 and 4 (each within the scatter of the next); then compound 2. At a limit, above all of these: compound 1.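

Within the data shown here, the change on the amide-type nitrogen in a ring, read in this assay as hydrogen in place of naphthalen-1-yl (a 1.9-fold higher number from compound 3 to compound 4 (0.27 log units; within the scatter)), is the first measured step at this position. With the rest of compound 3 held fixed, the loss of both six-membered aromatic rings of carbon only, 10 heavy atoms in all, leaves the number within the scatter. Nothing measured in this set bears on the reason for the size of this step.

The compounds shown leave open how a methyl group, a benzyl group or a longer chain ending in an amine on that nitrogen would read in this assay. Among these compounds, compounds 1 and 2 carry phenyl there but differ from compound 3 in more than one place, and no pair shows whether the step would remain within the scatter with a different chain on the shared core.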